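This account rests on a few compounds, and the source may have more. Where it says the series, first, only, none or still open, it means among the compounds named here.

Measured so far:
compound 1, `CN(c1ncco1)c1cnc(NCc2c(F)ccc3c2CCO3)n2cnnc12`: 67000 nM
compound 2, `CN(C)C(=O)c1cc(-c2cnc(NCc3c(F)ccc4c3CCO4)c3cn[nH]c(=O)c23)n(C)n1`: 3000 nM

In a physicochemical assay for solubility, read by LC-MS, in phosphate buffer, with a stated time of 24 h, at pH 7.4 (on this read-out lower numbers stand for lower solubility and higher numbers for higher solubility), compound 1 gives 67000 nM and stands highest of the two numbers; compound 2, built on a different core, gives 3000 nM, a gap beyond the scatter. Going by the values given here, no step between measured compounds that differ in one place is available, so no measured step guides the next change. Compound 3, `O=C(Nc1cnc(NCc2c(F)ccc3c2CCO3)n2cnnc12)c1ccccc1`, keeps the core of compound 1 and differs by benzamido in place of methyl(1,3-oxazol-2-yl)amino on an aromatic carbon. With nothing comparable measured, the step of a 3.4-fold lower number from compound 1 to compound 3 (0.53 log units; beyond the scatter) is expected to be a modest fall, beyond the scatter but not large. Compound 3 is estimated at 20000 nM, within 5000 nM to 60000 nM.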

Compound 3, solubility: 2000 nM
The estimate for compound 3 lay 10-fold (1.00 log units) above the measured number; the whole stated range lies above it.
By their numbers in this assay, from the lowest: compounds 3 and 2 (each within the scatter of the next); then compound 1.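

In this assay, going by these compounds alone, benzamido in place of methyl(1,3-oxazol-2-yl)amino on an aromatic carbon of the shared core gives a 34-fold lower number from compound 1 to compound 3 (1.53 log units; beyond the scatter) and is the first measured one-place step, showing that this position alone can move the read-out by a large amount. The change alters the ring, the heavy atoms, and the donors and acceptors together, so this one step does not separate their contributions. No measurement bearing on the origin of the step is at hand.

From the compounds shown here alone, whether an acetamido group, a simple amine or a carboxylic acid at this position would stay closer to compound 1 remains open. Also open, going by these compounds, is whether the step would carry over to the core of compound 2.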